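Shortening the acid chain on the indole-type core

The source may hold more compounds than are shown below. What is called first, only, known or untested is meant among the compounds shown, and "the series" means these compounds.

Of the compounds shown here, three sharing one core have been tested in an assay on isolated protein for displacement of a labelled ligand from thyroid hormone receptor beta (Homo sapiens), with a stated time of 3 h; a lower number here means a stronger inhibitor, a higher number a weaker inhibitor. Compound 1 `Cc1cc2cc(NC(=O)C(=O)O)ccc2n1Cc1ccc(O)c(C(C)C)c1` gives 1500 nM. Compound 2 `Cc1cc2c(NC(=O)CC(=O)O)cccc2n1Cc1ccc(O)c(C(C)C)c1` gives 230 nM. Compound 3 `Cc1c(CCCCC(=O)O)c2ccccc2n1Cc1ccc(O)c(C(C)C)c1` gives 1400 nM, the second highest of the three numbers; its number sits within the scatter of compound 1 and is beyond the scatter from compound 2, which shows the lowest number of the three.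

Compound 4 `Cc1c(CCC(=O)O)c2ccccc2n1Cc1ccc(O)c(C(C)C)c1` is not yet measured. It differs from compound 3 in one place: carboxy in place of 2-carboxyethyl on a saturated chain carbon, two bonds along the chain from an aromatic carbon, so the acid sits on a shorter chain. Going by the values given here, no measured pair shows this same change, so its size has to be guessed from the spread of the three measured numbers alone. A modest drop in the number is expected, so that the step of a 2.3-fold lower number from compound 3 to compound 4 (0.37 log units; beyond the scatter) is estimated to fall at or just beyond the scatter. For compound 4 the expected value in this assay is 600 nM, with a range from 150 nM to 2500 nM.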

Compound 4, half-maximal inhibitory concentration: 760 nM
Compound 4: the middle estimate sits 1.3-fold (0.10 log units) below what was measured, and the stated range covers the measured number.
By their numbers in this assay, from the lowest: compound 2; then compounds 4, 3 and 1 (each within the scatter of the next).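

In this assay, replacing 4-carboxybutyl with 2-carboxyethyl on the shared core gives a 1.8-fold lower number from compound 3 to compound 4 (0.27 log units; within the scatter). Going by these compounds alone, this is the first pair that differs only in the length of the acid chain, and it shows that removing this much of the chain at this position leaves the two numbers indistinguishable within the usual scatter of the assay. Nothing measured here offers an explanation for this result.

From the compounds shown here alone, a single pair cannot show a trend, so it remains open how the number would respond to a shorter carboxymethyl chain or to a chain longer than 4-carboxybutyl. Going by these compounds, it is also open whether the acid itself is needed at this position, which an amine in its place on the same chain would help to test.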